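Removing One Trifluoromethyl: What the Cell Assay Should Show

The compounds below may be only part of what the source reports. "The series", "measured", "known", "first", "only" and "open" are said of these compounds alone.

Compound 1 `O=C(Nc1cccc(-n2cc(-c3ccncc3)c(-c3cc(O)cc(Cl)c3)n2)c1)Nc1ccc(Cl)c(Cl)c1`: 96%
Compound 2 `COc1cc(Cl)cc(-c2nn(-c3cccc(NC(=O)Nc4cc(C(F)(F)F)cc(C(F)(F)F)c4)c3)cc2-c2ccncc2)c1`: 100%

In a functional assay on A549 cells (Homo sapiens) for inhibition, read by sulforhodamine B assay, with a stated time of 48 h, tested at 0.01 uM (a higher number here means a weaker effect of the compound at the concentration tested, a lower number a stronger effect), compound 1 gives 96% and compound 2 gives 100%. Compound 2 has the higher of the two numbers, but the gap to compound 1 lies within the scatter, so no order between them can be read. Both numbers sit close to full activity, which means that neither compound holds the cells back much at this concentration.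

Compound 3 `COc1cc(Cl)cc(-c2nn(-c3cccc(NC(=O)Nc4cccc(C(F)(F)F)c4)c3)cc2-c2ccncc2)c1` differs from compound 2 in one place: hydrogen in place of trifluoromethyl on an aromatic carbon. One of the two trifluoromethyl groups on that ring is lost; the other stays.

For the measured compounds named here, no step between two measured compounds is available to guide the expectation. Because compound 2 gives 100% and the numbers leave little room upward, the step in this assay is expected to be a number 3 percentage points lower from compound 2 to compound 3 (within the scatter), nothing beyond the scatter in either direction. Compound 3 is therefore estimated at 97%, within a range from 86% to 106%.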

Compound 3, a percentage reported as activity, at one concentration (the size of the read-out at that concentration, not a potency): 100%
For compound 3 the middle estimate is 3 percentage points below the measured one; low and high end bracket the measured number.
By their numbers in this assay, from the lowest: compounds 1, 2 and 3 (each within the scatter of the next).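

In this assay, this first direct look at the position gives no change at the digits printed from compound 2 to compound 3 (within the scatter), so hydrogen in place of one trifluoromethyl on this aromatic carbon leaves the read-out as it was. Compound 2 and compound 3 both sit close to full activity at this single concentration, so the result shows only that neither holds the cells back much here, and any difference between them that might appear at a higher concentration would stay hidden. No measured information explains the result for this change.

From the compounds shown here alone, it remains open how the position behaves with a different group on that carbon, such as an amine or a carboxylic acid. Going by these compounds, it is also open whether the ring would give the same read-out with the remaining trifluoromethyl replaced by hydrogen as well.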